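Acylurea benzothiazole sulfones: amine tail swap

This account rests on a few compounds, and the source may have more. Where it says the series, first, only, none or still open, it means among the compounds named here.

Compound 1 `COCCNCCCS(=O)(=O)c1ccc2nc(NC(=O)NC(=O)c3ccccc3Cl)sc2c1` gives 8.6 nM in an assay on HEK293 cells for displacement of a labelled ligand from growth hormone secretagogue receptor type 1 (Homo sapiens), with a stated time of 60 min (on this read-out higher numbers stand for weaker inhibition and lower numbers for stronger inhibition), the highest of the three numbers here. Compound 3 `CN1CCC(S(=O)(=O)c2ccc3nc(NC(=O)NC(=O)c4cc5c(cc4Cl)CCN5C)sc3c2)CC1` gives 7.2 nM on this assay, a gap to compound 1 that lies within the scatter, so no order between the two is claimed. Compound 2 `CN1CCN(CCCS(=O)(=O)c2ccc3nc(NC(=O)NC(=O)c4cc(-n5cccn5)c(Cl)cc4Cl)sc3c2)CC1` gives 0.31 nM on this assay, well beyond the scatter from compound 1, though compound 2 also carries a different acyl aryl group, so the two values show only that the gap exists. Compound 4 `CCN(CC)CCCS(=O)(=O)c1ccc2nc(NC(=O)NC(=O)c3ccccc3Cl)sc2c1` differs from compound 1 in one place: diethylamino in place of (2-methoxyethyl)amino on a saturated chain carbon, three bonds along the chain from a sulfonyl sulfur. Among the measured compounds shown here, no measured pair isolates this change, so the step is expected to be small, at most modest toward a lower number. Compound 4 is expected to give 6 nM on this assay, in the range 2 nM to 20 nM, an estimated step of a 1.4-fold lower number from compound 1 to compound 4 (0.16 log units; within the scatter).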

Compound 4, half-maximal inhibitory concentration: 13 nM
Estimate against measurement, compound 4: 2.2-fold (0.34 log units) below, and the stated range covers the measured number.
By their numbers in this assay, from the lowest: compound 2; then compounds 3, 1 and 4 (each within the scatter of the next).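

Among the compounds shown here, on the saturated chain carbon, three bonds along the chain from a sulfonyl sulfur, diethylamino in place of (2-methoxyethyl)amino gives the first matched step at this position in this assay: a 1.5-fold higher number from compound 1 to compound 4 (0.18 log units; within the scatter). Exchanging the secondary amine with its hydrogen-bond donor for this tertiary amine therefore leaves the read-out unchanged within the scatter. Nothing available accounts for this outcome.

From the compounds shown here alone, a morpholine or a carboxylic acid on the same 3-carbon chain remains open. So does whether this exchange gives a similar step with the acyl aryl group of compound 2.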